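Compound 4 and a change already made once

The source may hold more compounds than are shown below. What is called first, only, known or untested is meant among the compounds shown, and "the series" means these compounds.

The measured compounds are:
compound 1, `CCc1ccc(Nc2cc(NC(=O)Nc3cc(OC)cc(OC)c3)ncn2)cc1`, with 66.2%;
compound 2, `COc1cc(NC(=O)Nc2cc(Nc3ccc(F)c(Cl)c3)ncn2)cc(OC)c1`, with 53.1%;
compound 3, `O=C(Nc1cc(Nc2ccc(F)c(Cl)c2)ncn1)Nc1c(Cl)cccc1Cl`, with 53.7%.

All three were tested in a functional assay on HCC827 cells (Homo sapiens) for inhibition, read by MTT assay, with a stated time of 48 h, tested at 10 uM; a higher number here means more inhibition at the concentration tested (going by the name of the read-out), a lower number less inhibition. Compound 1 sits highest of the three; compound 2 and compound 3 lie within the usual scatter of each other, so no order between them can be read. The gap from compound 3 up to compound 1 is beyond the scatter. How the core of compound 2 differs from the core of compound 3 is not broken down here.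

One change is made twice in this set. From compound 2 to compound 1 it reads (4-ethylphenyl in place of 3-chloro-4-fluorophenyl on a nitrogen on an aromatic ring), and it brought a number 13.1 percentage points higher from compound 2 to compound 1 (beyond the scatter), a modest step, yet beyond the scatter. The unmeasured compound 4, `CCc1ccc(Nc2cc(NC(=O)Nc3c(Cl)cccc3Cl)ncn2)cc1`, arises from compound 3 by the same change, (4-ethylphenyl in place of 3-chloro-4-fluorophenyl on a nitrogen on an aromatic ring), at a place described in the same words.

If that change behaves on the core of compound 3 as it did on the core of compound 2, compound 4 is expected to gain roughly as much, an estimated a number 12.3 percentage points higher from compound 3 to compound 4 (beyond the scatter), resting on the one earlier step of a number 13.1 percentage points higher from compound 2 to compound 1 (beyond the scatter). For the measured compounds named here, with only a single precedent, the expectation is held loosely. Compound 4 is therefore estimated at 66%, with a likely range from 53% to 79%.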

Compound 4, a percentage reported as inhibition, at one concentration (the size of the read-out at that concentration, not a potency): 58%
Estimate against measurement, compound 4: 8 percentage points above, within the range that was stated.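

In this assay, putting 4-ethylphenyl in place of 3-chloro-4-fluorophenyl on a second core gave a number 4.3 percentage points higher from compound 3 to compound 4 (within the scatter), so on this core the step alone cannot be told apart from the ordinary spread of repeated measurements. Set beside the earlier step, the two sizes cannot be separated either: the same change on two cores in this assay, a number 13.1 percentage points higher (beyond the scatter) from compound 2 to compound 1 and a number 4.3 percentage points higher (within the scatter) from compound 3 to compound 4, 8.8 percentage points apart, within the scatter of two such steps. For the compounds shown here, this shows that the change did not reverse direction on the second core and gives no sign that the core alters its effect, but it does not show that the step carries over at the same size, since it passed beyond the scatter on only one of the two cores, and two pairs at a single concentration give no rule for any other core.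

The compounds shown leave open whether the change would behave in the same way on a third core, and what a longer chain in place of the ethyl, or an amine or a carboxylic acid on that phenyl, would do to the inhibition. They also leave open how these compounds compare in potency, as each is represented by a reading at one concentration only.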